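The source may report more compounds than this note shows. Statements on the series, on what has been measured and on what is new or still open speak of the compounds shown alone.

- Compound 1 `O=C(Nc1ccc(F)cc1)N1CCN(S(=O)(=O)c2sccc2-c2ccccc2Oc2ccc(O)c(O)c2)CC1`: 15500 nM
- Compound 2 `COc1ccc(Oc2ccccc2-c2ccsc2S(=O)(=O)N2CCN(C(=S)Nc3ccc(Cl)cc3)CC2)cc1OC`: > 20000 nM

In an ADME assay on HEK-293T cells (Homo sapiens) for cytotoxicity, read by CCK-8 assay, with a stated time of 48 h (on this read-out higher numbers stand for weaker inhibition and lower numbers for stronger inhibition), compound 2 gives > 20000 nM, which is a limit of the assay and not a number. Compound 3 `COc1ccc(Oc2ccccc2-c2ccsc2S(=O)(=O)N2CCN(C(=O)Nc3ccc(F)cc3)CC2)cc1OC` differs from compound 2 in one place, on an amine nitrogen in a ring: a group of 10 heavy atoms (7 carbon, 1 nitrogen, 1 oxygen, 1 fluorine; one six-membered aromatic ring of carbon only) in place of a group of 10 heavy atoms (7 carbon, 1 nitrogen, 1 sulfur, 1 chlorine; one six-membered aromatic ring of carbon only), on an amine nitrogen in a ring. The entering (4-fluorophenyl)carbamoyl also occurs in compound 1, which gives 15500 nM in this assay, so a similar value is expected for compound 3. The expected at least 1.1-fold lower number from compound 2 to compound 3 (0.07 log units; that floor lies within the scatter) is small, probably within the usual scatter. Compound 3 is estimated at 17000 nM, with an expected range of 8000 nM to 30000 nM.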

Compound 3, half-maximal inhibitory concentration: > 50000 nM
Compound 3 ended at the assay's limit; the forecaster's own chance of this, stated with the estimate: 40%; middle value at least 2.9-fold (0.46 log units) away from the limit.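

In this assay, 3,4-dimethoxyphenyl in place of 3,4-dihydroxyphenyl on an oxygen on an aromatic ring gives an at least 3.2-fold higher number from compound 1 to compound 3 (0.50 log units; beyond the scatter), so here the two hydroxy groups go with the stronger inhibition. For compound 3, > 50000 nM is a limit of the assay and not a number, so the true step may be larger. The step on the amine nitrogen, from compound 2 to compound 3, cannot be read.

Going by these compounds, what 4-hydroxyphenyl or 3-hydroxy-4-methoxyphenyl would give at this position remains open, so it is unclear whether both hydroxy groups are needed. On these data alone, how the two groups on the amine nitrogen compare also remains open.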